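A few compounds are considered here, and "the series" means these few. Any claim that something is new, unique, unknown or untested is made for them only; others in the source may bear on it.

Measured so far in a functional assay on NALM-6 cells (Homo sapiens) for cytotoxicity, with a stated time of 72 h; a higher number here means that more compound is needed for the effect, a lower number that less compound is needed:
compound 1 `C=C[C@@](C)(/C=C/c1ccc(OCc2ccccc2)cc1)CCC=C(C)C`: > 43400 nM (a limit)
compound 2 `C=C[C@@](C)(/C=C/c1ccc(Nc2ccc(Cl)c(Cl)c2)cc1)CCC=C(C)C`: > 43400 nM (a limit)

Compound 2 gives no number, only the limit > 43400 nM. Compound 1 is also reported only as a limit. Going by the values given here, the whole series so far therefore rests on (the limit of > 43400 nM in this assay, at which 2 of the 2 values shown sit), and no ranking of the two compounds can be read from it.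

The next change leads to compound 3 `C=C[C@@](C)(/C=C/c1ccc(-c2ccccc2)cc1)CCC=C(C)C`: phenyl in place of (3,4-dichlorophenyl)amino on an aromatic carbon, para to a large group (phenyl in place of (3,4-dichlorophenyl)amino on an aromatic carbon).

Among the compounds with values here, the one measured step that bears on this change is a step that the two limits leave unreadable from compound 1 to compound 2, which also exchanges a group on an aromatic carbon. It offers no size to carry over. Within the data shown here, no step of readable size is therefore expected in this assay, and no direction can be named. The estimated step is a step that the limit leaves unreadable from compound 2 to compound 3, and another report as a limit is the likeliest outcome. For compound 3 the expected value is 45000 nM, with an estimated range of 15000 nM to 90000 nM.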

Compound 3, half-maximal effective concentration: > 43400 nM
Compound 3: only a limit was reported; the forecaster's own chance of this, stated with the estimate: 75%; the middle value lies beyond the limit too.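

In this assay compound 3 is also reported only as a limit (> 43400 nM) and gives no number. Going by these compounds alone, no step among compound 1, compound 2 and compound 3 can be read, and the series still rests on one value: (the limit of > 43400 nM in this assay, at which 3 of the 3 values shown sit). The compounds shown leave open whether any group at this aromatic carbon gives a readable value in this assay at all.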